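This account rests on a few compounds, and the source may have more. Where it says the series, first, only, none or still open, it means among the compounds named here.

Compound 1 `Clc1ccc2c(NCCNc3ccc(Br)cc3)ccnc2c1`: in a toxicity assay on Huh-7 cells (Homo sapiens) for cytotoxicity, read by MTT assay, with a stated time of 72 h (a lower number here means that less compound is tolerated, a higher number that more compound is tolerated), compound 1 gives > 100 ug/mL, which is a limit of the assay and not a number.
Compound 2 `N#Cc1ccc(NCCNc2ccnc3cc(Cl)ccc23)cc1`: in this assay compound 2 gives 39.6 ug/mL.
Compound 3 `Clc1ccc2c(NCCNc3ccccc3Cl)ccnc2c1`: in this assay compound 3 gives > 100 ug/mL, again a limit and not a number.

Compound 3 therefore stands at the top of what was measured in this assay, and the same is true of one other compound, as shown by the limit of > 100 ug/mL in this assay, at which 2 of the 3 values shown sit. The next compound, compound 4 `Cc1ccc(NCCNc2ccnc3cc(Cl)ccc23)cc1`, differs from compound 3 in one place: 4-methylphenyl in place of 2-chlorophenyl on an amine nitrogen. Among the measured compounds shown here, two measured steps bear on this change. Going by these compounds, the step that the two limits leave unreadable from compound 1 to compound 3 exchanged the same aryl group, but both of its ends are limits, so its size is unknown. The step of an at least 2.5-fold lower number from compound 1 to compound 2 (0.40 log units; beyond the scatter) shows that a change of a single group on that aryl ring can move the number. Starting from a limit, the step is expected to be a number no higher from compound 3 to compound 4 (the limit leaves the size open), with compound 4 most likely staying at or near the limit in this assay. Compound 4 is estimated at 100 ug/mL, within a range from 40 ug/mL to 250 ug/mL.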

Compound 4, half-maximal cytotoxic concentration: > 100 ug/mL
Compound 4: no number, only a limit; the forecaster's own chance of this, stated with the estimate: 60%; the middle value sits exactly at the limit.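

Putting methyl in place of cyano on an aromatic carbon gives an at least 2.5-fold higher number from compound 2 to compound 4 (0.40 log units; beyond the scatter), so the lower number of compound 2 in this assay now stands against two other groups at that place, bromo in compound 1 and methyl in compound 4. The steps from compound 3 to compound 4 and from compound 1 to compound 4 cannot be read, as both ends of each are limits and not numbers. Compound 2 is therefore the only compound shown with a number, while the others share a single limit: the limit of > 100 ug/mL in this assay, at which 3 of the 4 values shown sit.

Going by these compounds, how far compound 1, compound 3 and compound 4 lie beyond that limit stays open, so no order among them can be given. Also open, on these data alone, is whether an amine, a carboxylic acid or a longer chain on that aryl ring would bring the number down as the cyano group does.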